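This account rests on a few compounds, and the source may have more. Where it says the series, first, only, none or still open, it means among the compounds named here.

Compound 1 `Cc1ccc(OCC(=O)N(Cc2cccs2)CC(C)C)cc1` gives 900 nM.
Compound 2 `CCN(Cc1cccnc1)C(=O)COc1ccc(C)cc1` gives 15400 nM.
Compound 3 `CCN(Cc1ccco1)C(=O)COc1ccc(C)cc1` gives 489 nM.

All three were tested in an assay on HEK293 cells for agonist activity at transient receptor potential cation channel subfamily M member 8 (Homo sapiens), read by fluorescence and calcium flux, with a stated time of 15 min; on this read-out lower numbers stand for an effect already at smaller amounts and higher numbers for an effect only at larger amounts of compound. On these numbers compound 1 stands second highest of the three: compound 3 lies close to it, within the usual scatter, while compound 2 sits far above it, beyond the scatter. Among the measured compounds shown here, the only step among the measured compounds that changes a single place is a 31-fold lower number from compound 2 to compound 3 (1.50 log units; beyond the scatter), and that change sits on the saturated chain carbon bound to the amide nitrogen, not on the nitrogen's other substituent.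

Compound 4 `Cc1ccc(OCC(=O)N(Cc2cccs2)C2COC2)cc1` differs from compound 1 in another place, namely (oxetan-3-yl in place of isobutyl on an amide-type nitrogen). For the measured compounds named here, no measured step touches this part of the shared core, so the measured data give no direct guide to the size or direction of the change. The expectation for compound 4 in this assay is therefore cautious and wide, centred on 1800 nM with a range from 450 nM to 7200 nM. This estimate corresponds to a 2.0-fold higher number from compound 1 to compound 4 (0.30 log units; within the scatter), a step expected to stay near the scatter.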

Compound 4, half-maximal effective concentration: 23000 nM
Beside the measured number, compound 4's estimate is 13-fold (1.11 log units) below it; measured number outside the range, above it.
By their numbers in this assay, from the lowest: compounds 3 and 1 (each within the scatter of the next); then compounds 2 and 4 (each within the scatter of the next).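

In this assay the exchange of isobutyl for oxetan-3-yl on the amide-type nitrogen brings a 26-fold higher number from compound 1 to compound 4 (1.41 log units; beyond the scatter) and so shows that this position, untouched by any earlier single-place step, does not accept every group alike. The two groups match in heavy-atom count, so the step does not follow from a change in that count; what enters is a four-membered non-aromatic ring with an oxygen that counts as a hydrogen-bond acceptor, which isobutyl lacks. No measured evidence explains the step.

The compounds shown do not separate the ring from its oxygen: cyclobutyl would have the ring without the oxygen, and 2-methoxyethyl an ether oxygen in an open chain. Going by these compounds, how a longer chain such as n-hexyl would fare at this nitrogen also stays open.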